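Cyclohexyl for benzyl on the amide of compound 1

A few compounds are considered here, and "the series" means these few. Any claim that something is new, unique, unknown or untested is made for them only; others in the source may bear on it.

Compound 1 `C=CC1=C(C(=O)NCc2ccccc2)C(c2ccc(OC)c(OC)c2)OC1` is the reference point of this set. In a functional assay on SW480 cells (Homo sapiens) for cytotoxicity, read by MTT assay, with a stated time of 24 h (on this read-out lower numbers stand for stronger inhibition and higher numbers for weaker inhibition), compound 1 gives only a limit, > 100000 nM. Compound 3 `C=CC1=C(C(=O)Nc2ccccc2OC)C(c2ccc(Cl)c(Cl)c2)OC1` likewise returns only a limit in this assay, > 100000 nM. Compound 1 thus stands at the limit of > 100000 nM in this assay, at which 2 of the 3 values shown sit, and no number places it more precisely. Going by the values given here, compound 2 `C=CC1=C(C(=O)NCc2ccccc2)C(c2ccc(OC)cc2)OC1` supplies the one measured number: in this assay compound 2 gives 39500 nM. Among the compounds with values here, the sole step between measured compounds, an at least 2.5-fold lower number from compound 1 to compound 2 (0.40 log units; beyond the scatter), concerns an aromatic carbon and not the amide nitrogen.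

Compound 4 `C=CC1=C(C(=O)NC2CCCCC2)C(c2ccc(OC)c(OC)c2)OC1` differs from compound 1 by cyclohexyl in place of benzyl on an amide-type nitrogen. Within the data shown here, no measured pair changes the group on the amide nitrogen, so none of the measured steps bears directly on this change. With compound 1 itself at a limit, the expected step is a number no higher from compound 1 to compound 4 (the limit leaves the size open), with no direction favoured beyond the scatter. Compound 4 is therefore estimated at about 100000 nM in this assay, within 30000 nM to 300000 nM, and most likely reported again only as a limit.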

Compound 4, half-maximal inhibitory concentration: 19100 nM
Compound 4: the middle estimate sits 5.2-fold (0.72 log units) above what was measured; the measured number lies below the stated range.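

Cyclohexyl in place of benzyl on the amide-type nitrogen gives an at least 5.2-fold lower number from compound 1 to compound 4 (0.71 log units; beyond the scatter) in this assay, so this position, which no earlier measured pair touched, does shift the read-out. An aromatic ring on this nitrogen is thus not needed for a measured value in this assay: with the rest of compound 1 kept, the non-aromatic cyclohexyl ring yields a number. The true size of the step stays open, since compound 1 is fixed only by a limit: the limit of > 100000 nM in this assay, at which 2 of the 4 values shown sit.

Going by these compounds alone, whether cyclohexyl has the same effect with the single methoxy of compound 2 remains open. The compounds shown also say nothing about an open chain such as n-hexyl on this nitrogen, or about a cyclohexyl ring carrying an amine or a carboxylic acid.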